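From Fluoro to Chloro on a Shared Core

A few compounds are considered here, and "the series" means these few. Any claim that something is new, unique, unknown or untested is made for them only; others in the source may bear on it.

In a functional assay on NCI-H460 cells (Homo sapiens) for inhibition, read by MTT assay, with a stated time of 48 h (on this read-out lower numbers stand for stronger inhibition and higher numbers for weaker inhibition), compound 1 (`O=C(CC(c1ccc(Cl)cc1)C(C(=O)Nc1ccccn1)C(=O)Nc1ccccn1)c1ccccc1`) gives 18900 nM and compound 3 (`O=C(CC(c1ccc(F)cc1)C(C(=O)Nc1ccccn1)C(=O)Nc1ccccn1)c1ccc(F)cc1`) gives 20100 nM as its half-maximal inhibitory concentration. Compound 2 (`O=C(CC(c1ccccc1)C(C(=O)Nc1ccccn1)C(=O)Nc1ccccn1)c1ccc(F)cc1`) is recorded as "not active" (no number reported) without any number. Going by the values given here, compound 3 therefore stands level with compound 1, as their two values lie within the scatter of each other, and these are the only two numbers available.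

Compound 4 (`O=C(CC(c1ccc(Cl)cc1)C(C(=O)Nc1ccccn1)C(=O)Nc1ccccn1)c1ccc(F)cc1`) has not yet been measured. It differs from compound 3 in one place (chloro in place of fluoro on an aromatic carbon), with chloro in place of fluoro on an aromatic carbon, para to a large group, so that a 4-fluorophenyl becomes a 4-chlorophenyl. Among the compounds with values here, no measured pair shows this change directly, so the expectation rests on compound 1 at 18900 nM and compound 3 at 20100 nM as neighbouring values. In this assay the expected 1.1-fold lower number from compound 3 to compound 4 (0.05 log units; within the scatter) stays within the scatter, with no firm direction. Compound 4 is expected at 18000 nM (estimated range 10000 nM to 35000 nM).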

Compound 4, half-maximal inhibitory concentration: 26800 nM
Compound 4: middle estimate off by 1.5-fold (0.17 log units), on the low side, within the range that was stated.
By their numbers in this assay, from the lowest: compounds 1, 3 and 4 (each within the scatter of the next).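

In this assay, chloro in place of fluoro at this position now has a direct reading, turning a 4-fluorophenyl into a 4-chlorophenyl: a 1.3-fold higher number from compound 3 to compound 4 (0.12 log units; within the scatter) lies within the scatter, so the two halogens cannot be told apart here. Fluoro in place of hydrogen on an aromatic carbon of the other ring also has its first reading, a 1.4-fold higher number from compound 1 to compound 4 (0.15 log units; within the scatter), which is likewise within the scatter. Compound 3 with fluoro and compound 4 with chloro both give numbers, whereas compound 2, with hydrogen in that place, is recorded as not active.

Whether a methoxy group, a trifluoromethyl group or an amine at this position would give a value outside the scatter of these compounds remains open. No other measurement bears on these results, and what lies behind them remains unexplained.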